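A Methyl on the Piperidine Ring of Compound 1

The compounds below may be only part of what the source reports. "The series", "measured", "known", "first", "only" and "open" are said of these compounds alone.

The measured compounds:
compound 1, `COc1cc2c(Oc3ccc(NC(=O)c4cc(-c5ccccc5)nc5ccccc45)cc3F)ccnc2cc1OCCCN1CCCCC1`, gives 1490 nM.
compound 3, `COc1cc2c(Oc3ccc(NC(=O)c4cc(-c5cccc(Cl)c5)nc5ccccc45)cc3F)ccnc2cc1OCCCN1CCCCC1`, gives 150 nM.
compound 2, `COc1cccc(-c2cc(C(=O)Nc3ccc(Oc4ccnc5cc(OCCCN6CCCCC6)c(OC)cc45)c(F)c3)c3ccccc3n2)c1`, gives "not determined" (no result reported) in a functional assay on U-87MG ATCC cells (Homo sapiens) for cytotoxicity, read by MTT assay, with a stated time of 72 h (on this read-out lower numbers stand for stronger inhibition and higher numbers for weaker inhibition), so it has no result there.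

Going by the values given here, compound 1 stands at the highest of the two numbers in this assay; the only other number, from compound 3, is lower by a 9.9-fold lower number from compound 1 to compound 3 (1.00 log units; beyond the scatter), a change on an aromatic carbon of the phenyl attached to the shared core. Compound 2 contributes no number.

Compound 4, `COc1cc2c(Oc3ccc(NC(=O)c4cc(-c5ccccc5)nc5ccccc45)cc3F)ccnc2cc1OCCCN1CCC(C)CC1`, differs from compound 1 by methyl in place of hydrogen on a saturated ring carbon. This change sits far from the place altered between compound 1 and compound 3, at a saturated ring carbon of the six-membered ring that bears the nitrogen at the end of the side chain. Among the compounds with values here, no measured pair in the set varies that ring, so the one known step, a 9.9-fold lower number from compound 1 to compound 3 (1.00 log units; beyond the scatter), does not bear on it and offers no guide to direction. With nothing to argue for movement, the expected outcome is a step within the scatter, in no particular direction, so that the estimated step from compound 1 to compound 4 is a 1.0-fold higher number from compound 1 to compound 4 (0.00 log units; within the scatter). Compound 4 is therefore estimated at 1500 nM, with a range from 500 nM to 4500 nM.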

Compound 4, half-maximal inhibitory concentration: 920 nM
Compound 4: the middle estimate sits 1.6-fold (0.21 log units) above what was measured; measured number inside the range.
By their numbers in this assay, from the lowest: compound 3; then compounds 4 and 1 (each within the scatter of the next).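

In this assay, going by these compounds alone, the result, a 1.6-fold lower number from compound 1 to compound 4 (0.21 log units; within the scatter), gives the first reading on the saturated ring at the end of the side chain, which all the earlier compounds carry as an unsubstituted piperidin-1-yl. Going from piperidin-1-yl to 4-methylpiperidin-1-yl, with the methyl three ring bonds from the ring nitrogen, therefore moves the number by no more than repeated measurements would, whereas the chloro change on the phenyl, a 9.9-fold lower number from compound 1 to compound 3 (1.00 log units; beyond the scatter), lies beyond the scatter, so in compound 1 this ring carbon accepts one added methyl with no change that can be told from noise. Nothing measured here speaks to why the number holds at this position.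

As far as these compounds go, whether this holds for other groups on the same ring carbon, such as a hydroxyl, an amine, a carboxylic acid or a longer chain such as ethyl, stays open, as does the effect of replacing the piperidine ring with a morpholine ring. From the compounds shown here alone, it is equally open whether the 4-methylpiperidin-1-yl group would leave the number unmoved in the presence of the chloro of compound 3.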